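The source may hold more compounds than are shown below. What is called first, only, known or untested is meant among the compounds shown, and "the series" means these compounds.

Measured so far in a functional assay on NCI/ADR cells (Homo sapiens) for cytotoxicity, read by sulforhodamine B assay; on this read-out lower numbers stand for stronger inhibition of growth and higher numbers for weaker inhibition of growth:
- compound 1 `CC1=CC[C@@H]([C@@](C)(O)CCCC(C)(C)NC(=S)N/N=C\c2ccccc2[N+](=O)[O-])CC1`: 20400 nM
- compound 2 `CC1=CC[C@@H]([C@@](C)(O)CCCC(C)(C)NC(=S)N/N=C\c2ccccc2Cl)CC1`: > 100000 nM (a limit of the assay, not a number)
- compound 3 `CC1=CC[C@@H]([C@@](C)(O)CCCC(C)(C)NC(=S)N/N=C\c2cccc(Cl)c2)CC1`: 7350 nM

Compound 3 gives the lowest number of the three, with a 2.8-fold lower number from compound 1 to compound 3 (0.44 log units; beyond the scatter), a modest step. Compound 4 `CC1=CC[C@@H]([C@@](C)(O)CCCC(C)(C)NC(=S)N/N=C\c2ccc(Cl)cc2)CC1` has the same atoms as compound 3, joined differently: 4-chlorophenyl in place of 3-chlorophenyl on a carbon with a double bond to nitrogen.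

The closest measured change is an at least 13-fold lower number from compound 2 to compound 3 (1.13 log units; beyond the scatter), a large step between two chlorophenyl compounds. It shows that the place of the chlorine can matter a great deal in this series. Among the compounds with values here, no measured compound carries 4-chlorophenyl, so that step fixes neither size nor direction here. The working expectation stays close to compound 3 at 7350 nM, with a slight lean toward a higher number and a wide allowance on that side.

The expected step is a 1.6-fold higher number from compound 3 to compound 4 (0.21 log units; within the scatter).

For compound 4 the estimate is 12000 nM, with an expected range of 3500 nM to 45000 nM.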

Compound 4, concentration for 50% growth inhibition: 7580 nM
For compound 4 the middle estimate is 1.6-fold (0.20 log units) above the measured one; the range from low to high includes it.
By their numbers in this assay, from the lowest: compounds 3 and 4 (each within the scatter of the next); then compound 1. At a limit, above all of these: compound 2.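

In this assay, the chlorine reads the same on 3-chlorophenyl and 4-chlorophenyl, with a 1.0-fold higher number from compound 3 to compound 4 (0.01 log units; within the scatter). Among the chlorophenyl compounds, 2-chlorophenyl alone now stands apart, with an at least 13-fold lower number from compound 2 to compound 4 (1.12 log units; beyond the scatter), and the value of compound 2 is a limit of the assay, not a number: the limit of > 100000 nM in this assay, at which 1 of the 4 values shown sits. The advantage over 2-nitrophenyl is no longer tied to 3-chlorophenyl, since 4-chlorophenyl also shows it, with a 2.7-fold lower number from compound 1 to compound 4 (0.43 log units; beyond the scatter).

Still open, from the compounds shown here alone, is whether the match between 3-chlorophenyl and 4-chlorophenyl extends to other groups, such as 3-nitrophenyl, 4-nitrophenyl or 4-methoxyphenyl. The compounds shown also leave open how much of the activity needs the chlorine at all, as an unsubstituted phenyl is not among them.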